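Aryl swap on the amide-type nitrogen of compound 2

The source may report more compounds than this note shows. Statements on the series, on what has been measured and on what is new or still open speak of the compounds shown alone.

Measured so far:
compound 1 `NC(=O)c1c(NC(=O)c2ccccc2Cl)sc2c1CCN(Cc1ccc(Cl)cc1Cl)C2`: 8010 nM
compound 2 `NC(=O)c1c(NC(=O)c2ccccc2Cl)sc2c1CCN(C(=S)Nc1ccc(C(F)(F)F)cc1)C2`: 7590 nM

In a functional assay on HL-60 cells (Homo sapiens) for antiproliferative activity, with a stated time of 24 h (a lower number here means a stronger inhibitor, a higher number a weaker inhibitor), compound 2 gives 7590 nM. In this assay compound 1 gives 8010 nM, and the two numbers lie within the scatter of each other, so neither compound can be set apart from the other on these data; both sit at the weak end.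

Compound 3 `NC(=O)c1c(NC(=O)c2ccccc2Cl)sc2c1CCN(C(=S)Nc1c(Cl)cccc1Cl)C2` differs from compound 2 in one place: 2,6-dichlorophenyl in place of 4-(trifluoromethyl)phenyl on an amide-type nitrogen. Among the compounds with values here, no measured pair shows a change of this kind, so the size of the step has no direct precedent here. Within the data shown here, with only two weak compounds in hand and no step beyond the scatter among them, the step from compound 2 to compound 3 is expected to be a 1.1-fold lower number from compound 2 to compound 3 (0.04 log units; within the scatter), that is, nothing beyond the scatter in either direction. Compound 3 is therefore estimated at 7000 nM, with a range from 2500 nM to 20000 nM.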

Compound 3, half-maximal inhibitory concentration: 3950 nM
Compound 3: middle estimate off by 1.8-fold (0.25 log units), on the high side; the measured number falls inside the stated range.
By their numbers in this assay, from the lowest: compounds 3, 2 and 1 (each within the scatter of the next, the first and the last beyond it).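

In this assay, placing 2,6-dichlorophenyl where 4-(trifluoromethyl)phenyl stood on the amide-type nitrogen gives a 1.9-fold lower number from compound 2 to compound 3 (0.28 log units; within the scatter), so this aryl change does not separate the two compounds. Within the data shown here, the other comparison, which concerns the group on the amine nitrogen in a ring, gives a 2.0-fold lower number from compound 1 to compound 3 (0.31 log units; beyond the scatter), the first step beyond the scatter, though only a modest one. Nothing at hand explains either step.

As far as these compounds go, whether an unsubstituted phenyl, a single chlorine on the ring or an alkyl chain in place of the aryl group would move the number clearly beyond the scatter at this nitrogen remains open. Also open, from the compounds shown here alone, is whether a carbonyl in place of the thiocarbonyl carbon would leave the number of compound 3 within the scatter.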